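A few compounds are considered here, and "the series" means these few. Any claim that something is new, unique, unknown or untested is made for them only; others in the source may bear on it.

Compound 1 `CCn1c(C(=O)NCCN(C)C)ccc1C(CC)(CC)c1ccc(OCCC(O)(CC)CC)c(C)c1`: 82 nM
Compound 2 `CCN(CC)CCNC(=O)c1ccc(C(CC)(CC)c2ccc(OCCC(O)(CC)CC)c(C)c2)n1CC`: 2.3 nM
Compound 3 `CCOc1ccc(NC(=O)c2ccc(C(CC)(CC)c3ccc(OCCC(O)(CC)CC)c(C)c3)n2CC)cc1`: 1630 nM

All three were tested in an assay on cells for agonist activity at vitamin D3 receptor (Homo sapiens), with a stated time of 96 h; on this read-out lower numbers stand for an effect already at smaller amounts and higher numbers for an effect only at larger amounts of compound. Compound 2 gives the lowest of the three numbers, with a 36-fold lower number from compound 1 to compound 2 (1.55 log units; beyond the scatter) and a 710-fold higher number from compound 2 to compound 3 (2.85 log units; beyond the scatter), both beyond the scatter. Compound 4 `CCC(C)C(NC(=O)c1ccc(C(CC)(CC)c2ccc(OCCC(O)(CC)CC)c(C)c2)n1CC)C(=O)O` has not yet been measured. It differs from compound 2 in one place: 1-carboxy-2-methylbutyl in place of 2-(diethylamino)ethyl on an amide-type nitrogen.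

The step that bears most on this change is a 710-fold higher number from compound 2 to compound 3 (2.85 log units; beyond the scatter), where the 2-(diethylamino)ethyl group on the amide-type nitrogen was also exchanged, there for a 4-ethoxyphenyl group, and a 20-fold higher number from compound 1 to compound 3 (1.30 log units; beyond the scatter) points the same way. Compound 4 likewise loses the 2-(diethylamino)ethyl group and carries a 1-carboxy-2-methylbutyl group instead, so a large rise in this assay is expected, of about a 520-fold higher number from compound 2 to compound 4 (2.72 log units; beyond the scatter). The expected value for compound 4 is 1200 nM, with a range from 150 nM to 10000 nM.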

Compound 4, half-maximal effective concentration: 860 nM
Estimate against measurement, compound 4: 1.4-fold (0.14 log units) above, and the stated range covers the measured number.
By their numbers in this assay, from the lowest: compound 2; then compound 1; then compounds 4 and 3 (each within the scatter of the next).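

In this assay, the high numbers at this amide-type nitrogen turn out not to be confined to the 4-ethoxyphenyl group, since a 1-carboxy-2-methylbutyl group, with no ring, also gives a 370-fold higher number from compound 2 to compound 4 (2.57 log units; beyond the scatter). The two groups cannot be told apart here, with a 1.9-fold lower number from compound 3 to compound 4 (0.28 log units; within the scatter). The loss also holds against the dimethylamino partner, with a 10-fold higher number from compound 1 to compound 4 (1.02 log units; beyond the scatter), so among these four compounds the two with a 2-(dialkylamino)ethyl group give the lowest numbers, and none goes against this.

Nothing measured here explains these steps. Still open, on these data alone, is whether a longer chain ending in a diethylamino group, or a methyl ester in place of the carboxylic acid, would stay near compound 2 or fall with compounds 3 and 4.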